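Aryl ether side-chain variations at the leukotriene receptor

The source may report more compounds than this note shows. Statements on the series, on what has been measured and on what is new or still open speak of the compounds shown alone.

Measured compounds:
compound 1 `CCCCc1cc(C(C)=O)c(O)cc1OCCCCC#N`, 13%
compound 2 `CCc1cc(C(C)=O)c(O)cc1OCCCCCCC(C)(C)C#N`, 30%
compound 3 `CCc1cc(C(C)=O)c(O)cc1OCCCC(C)(C)C(N)=O`, 51%

In an assay on isolated protein for binding affinity to leukotriene B4 receptor 1 (Homo sapiens), tested at 1 uM (a higher number here means more inhibition at the concentration tested (going by the name of the read-out), a lower number less inhibition), compound 3 stands highest of the three numbers; compound 2 sits a number 21 percentage points higher from compound 2 to compound 3 (beyond the scatter), and compound 1 gives 13%, the lowest, a gap beyond the scatter in both cases. Compound 1 and compound 2 differ in two places, so only their two values are stated.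

Compound 4 `CCc1cc(C(C)=O)c(O)cc1OCCCCCCS(C)(=O)=O` is not yet measured. It differs from compound 3 by 3-(methylsulfonyl)propyl in place of 1-carbamoyl-1-methylethyl on a saturated chain carbon, three bonds along the chain from an oxygen on an aromatic ring. Within the data shown here, the only step that bears on this position is a number 21 percentage points higher from compound 2 to compound 3 (beyond the scatter), where the chain bearing a nitrile was exchanged for the shorter carbamoyl-bearing chain. Compound 4 returns to a longer chain, now ending in a methylsulfonyl group, closer in length to the chain of compound 2 than to that of compound 3. Some of the gain seen in that step is therefore expected to be given back, so a downward step a number 16 percentage points lower from compound 3 to compound 4 (beyond the scatter) is expected, of modest size. For compound 4 the estimated value is 35%, within a range of 15% to 55%.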

Compound 4, a percentage reported as inhibition, at one concentration (the size of the read-out at that concentration, not a potency): 62%
Estimate against measurement, compound 4: 27 percentage points below; the measured number lies above the stated range.
By their numbers in this assay, from the lowest: compound 1; then compound 2; then compound 3; then compound 4.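

In this assay, the chain ending in methylsulfonyl does not give back what the shorter carbamoyl-bearing chain gained; the number rises further (a number 11 percentage points higher from compound 3 to compound 4 (beyond the scatter)). Against the chain ending in 1-cyano-1-methylethyl, methylsulfonyl at the same place gives a large gain (a number 32 percentage points higher from compound 2 to compound 4 (beyond the scatter)), so a longer chain does not by itself go with a lower number: compound 2 and compound 4 both carry one and stand far apart, which points to the end group as the part that matters at this place. No measurement at hand bears on what lies behind this gain.

Still open, on these data alone, is how a carboxylic acid or a sulfonamide would read at the end of the same chain, and whether methylsulfonyl holds its standing on a shorter chain. All readings come from a single concentration, so the order of compound 3 and compound 4 gives no potency.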